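A Bulkier Group Takes the Place of Acetyl

This account rests on a few compounds, and the source may have more. Where it says the series, first, only, none or still open, it means among the compounds named here.

For the measured compounds named here, in a functional assay on L5178Y cells (Mus musculus) for cytotoxicity, read by MTT assay (on this read-out lower numbers stand for stronger inhibition and higher numbers for weaker inhibition), compound 3 `CC(=O)c1ccc(OCCCCN2CCN(c3cccnc3)CC2)cc1` gives 69 nM, the only true number so far. Compound 1 `CC(=O)c1ccc(OCCCN2CCN(c3ncccn3)CC2)cc1` reads > 100 nM, which is a limit of the assay and not a number. Compound 2 `CCC(=O)c1ccc(OCCCN2CCN(c3ncccn3)CC2)cc1` reads > 100 nM, again a limit. Going by the values given here, the one measured step is a step that the two limits leave unreadable from compound 1 to compound 2, so it offers no size to carry forward. Compound 4 `CCC(C)(C)c1ccc(OCCCCN2CCN(c3cccnc3)CC2)cc1` differs from compound 3 by 1,1-dimethylpropyl in place of acetyl on an aromatic carbon. With no readable step as a guide, no direction can be argued, and no shift beyond the usual scatter in this assay is expected. The expected move is a 1.1-fold lower number from compound 3 to compound 4 (0.03 log units; within the scatter). The estimate for compound 4 is 65 nM, with a range of 25 nM to 170 nM.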

Compound 4, half-maximal inhibitory concentration: 9.23 nM
Estimate against measurement, compound 4: 7.0-fold (0.85 log units) above; the whole stated range lies above it.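

In this assay, 1,1-dimethylpropyl in place of acetyl on this aromatic carbon gives a readable change: a 7.5-fold lower number from compound 3 to compound 4 (0.87 log units; beyond the scatter). This position, para to a large group, therefore responds to what sits on it, and a group of carbon only, without the carbonyl of acetyl, keeps cytotoxicity and strengthens it. The earlier step could not show this, because both of its values are limits and not numbers: the limit of > 100 nM in this assay, at which 2 of the 4 values shown sit.

The compounds shown do not separate the added size of the new group from the loss of the carbonyl. As far as these compounds go, how a tert-butyl group or an amine on this carbon would read remains open.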